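This account rests on a few compounds, and the source may have more. Where it says the series, first, only, none or still open, it means among the compounds named here.

Measured so far in an ADME assay on HEK293 cells (Homo sapiens) for cytotoxicity, read by resazurin assay, with a stated time of 48 h; a higher number here means that more compound is tolerated, a lower number that less compound is tolerated:
Compound 1 `O=S(=O)(Nc1ccc(-c2nc3ccccc3o2)cc1)c1cccc(F)c1`: > 100000 nM
Compound 2 `CS(=O)(=O)Nc1ccc(-c2nc3ccccc3o2)cc1`: > 100000 nM

Compound 2 gives > 100000 nM, which is a limit of the assay and not a number. Going by the values given here, its exact position is therefore unknown, and the only other value is a limit too: the limit of > 100000 nM in this assay, at which 2 of the 2 values shown sit.

Compound 3 `O=S(=O)(Nc1ccc(-c2nc3ccccc3o2)cc1)c1cccs1` has thiophen-2-yl in place of methyl on a sulfonyl sulfur, and the rest of compound 2 stays the same: thiophen-2-yl in place of methyl on a sulfonyl sulfur.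

Among the compounds with values here, one measured step bears on this change, since it alters the group on the same sulfonyl sulfur: a step that the two limits leave unreadable from compound 1 to compound 2. It gives no size to carry over. Compound 1, with 3-fluorophenyl at that place, gives > 100000 nM, which is also a limit. With only this to go on, no step beyond the usual scatter is expected in this assay, and no direction can be given. The expected step is a number no higher from compound 2 to compound 3 (the limit leaves the size open). Compound 3 will most likely be reported as a limit as well. As a number, the estimate for compound 3 is 100000 nM, with an expected range from 40000 nM to 150000 nM.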

Compound 3, half-maximal cytotoxic concentration: > 100000 nM
Compound 3: a limit, no number; the forecaster's own chance of this, stated with the estimate: 80%; the middle value sits exactly at the limit.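

In this assay compound 3 gives > 100000 nM, which is a limit and not a number, and its steps to compound 1 and compound 2 cannot be read. All three compounds share one result: the limit of > 100000 nM in this assay, at which 3 of the 3 values shown sit. The compounds shown leave open whether changing the group on the sulfonyl sulfur alters how much compound is tolerated in this assay.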